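This account rests on a few compounds, and the source may have more. Where it says the series, first, only, none or still open, it means among the compounds named here.

Compound 1 `O=C(NO)c1ccc(CNC(=O)c2n[nH]cc2NC(=O)c2ccccc2Cl)cc1`: 6170 nM in a functional assay on NCI-H460 cells (Homo sapiens) for inhibition, read by CCK-8 assay, with a stated time of 72 h; on this read-out lower numbers stand for stronger inhibition and higher numbers for weaker inhibition
Compound 2 `Nc1ccccc1NC(=O)c1ccc(CNC(=O)c2n[nH]cc2NC(=O)c2ccccc2F)cc1`: 9990 nM
Compound 3 `Nc1ccccc1NC(=O)c1ccc(CNC(=O)c2n[nH]cc2NC(=O)c2ccccc2)cc1`: 6320 nM

Compound 3 stands second highest of these three numbers. Its nearest neighbour is compound 1, and that gap lies within the scatter; compound 2 is the furthest away, and that gap also lies within the scatter, so none of the three can be called stronger or weaker than another on this read-out.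

Compound 4 `Nc1ccccc1NC(=O)c1ccc(CNC(=O)c2n[nH]cc2NC(=O)c2ccccc2Cl)cc1` differs from compound 3 in one place: chloro in place of hydrogen on an aromatic carbon. Among the measured compounds shown here, only one measured step touches a halogen at this aromatic carbon, the one from fluoro to hydrogen, a 1.6-fold lower number from compound 2 to compound 3 (0.20 log units; within the scatter). For the measured compounds named here, compound 1 carries the same chloro group but also a different group at the far end of the molecule, so no single-place step connects it to compound 3; its value and that of compound 3 simply sit within the scatter of each other. A halogen at this aromatic carbon has so far not moved the number beyond the scatter, and no step beyond the scatter is expected in this assay for compound 4 either. The estimate for compound 4 is 6000 nM, within 3000 nM to 12000 nM, which means an expected 1.1-fold lower number from compound 3 to compound 4 (0.02 log units; within the scatter).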

Compound 4, half-maximal inhibitory concentration: 6360 nM
For compound 4 the middle estimate is 1.1-fold (0.03 log units) below the measured one; the measured number falls inside the stated range.
By their numbers in this assay, from the lowest: compounds 1, 3, 4 and 2 (each within the scatter of the next).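

In this assay, chloro in place of hydrogen on this aromatic carbon, ortho to a large group, gives no visible change (a 1.0-fold higher number from compound 3 to compound 4 (0.00 log units; within the scatter)), and chloro in place of fluoro at the same carbon also stays small (a 1.6-fold lower number from compound 2 to compound 4 (0.20 log units; within the scatter)). With compound 4 in hand, hydrogen, fluoro and chloro can all be compared directly at this one position, and none of the steps among them goes beyond the scatter, so this read-out does not separate these three substituents. Compound 4 also gives a direct link across the other changed site, where 2-aminophenyl in place of hydroxy on an amide-type nitrogen likewise stays within the scatter (a 1.0-fold higher number from compound 1 to compound 4 (0.01 log units; within the scatter)), and no measurement at hand offers an explanation for any of these flat results.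

On these data alone, whether a methoxy group, an amine or a carboxylic acid on this same aromatic carbon would produce a step beyond the scatter remains open. Also open is whether hydrogen or fluoro at this carbon would behave the same way with hydroxy on the amide-type nitrogen, since chloro is the only one of the three shown with that group.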